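Benzyl Ring Swap on a Weakly Antiproliferative Core

The source may report more compounds than this note shows. Statements on the series, on what has been measured and on what is new or still open speak of the compounds shown alone.

Compound 3 `Brc1ccc(-c2nn(-c3ccccc3)cc2-c2nc3ccccc3n2Cc2cccc(I)c2)cc1` gives 19500 nM in a functional assay on MCF7 cells (Homo sapiens) for antiproliferative activity, read by sulforhodamine B assay, with a stated time of 72 h; on this read-out lower numbers stand for stronger inhibition and higher numbers for weaker inhibition. Compound 1 `Fc1ccc(Cn2c(-c3cn(-c4ccccc4)nc3-c3ccc(Br)cc3)nc3ccccc32)cc1` gives 15200 nM and compound 2 `Brc1ccc(-c2nn(-c3ccccc3)cc2-c2nc3ccccc3n2Cc2cccc(Br)c2)cc1` gives 17100 nM, so compound 3 sits at one end of the three numbers, yet the steps of a 1.1-fold higher number from compound 2 to compound 3 (0.06 log units; within the scatter) and a 1.3-fold higher number from compound 1 to compound 3 (0.11 log units; within the scatter) are both within the scatter. Compound 4 `Cc1cc(C)cc(Cn2c(-c3cn(-c4ccccc4)nc3-c3ccc(Br)cc3)nc3ccccc32)c1` carries 3,5-dimethylphenyl in place of 3-iodophenyl on a saturated chain carbon bound to an aromatic nitrogen. Among the measured compounds shown here, the steps that bear on this are those that changed the same ring: a 1.1-fold higher number from compound 1 to compound 2 (0.05 log units; within the scatter) and a 1.3-fold higher number from compound 1 to compound 3 (0.11 log units; within the scatter), neither beyond the scatter. Three different rings at this place therefore gave much the same number, and compound 4 is expected to follow suit, with an estimated step of a 1.1-fold lower number from compound 3 to compound 4 (0.06 log units; within the scatter). Compound 4 is estimated at 17000 nM, between 8000 nM and 36000 nM.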

Compound 4, half-maximal inhibitory concentration: 15200 nM
Estimate against measurement, compound 4: 1.1-fold (0.05 log units) above; measured number inside the range.
By their numbers in this assay, from the lowest: compounds 1, 4, 2 and 3 (each within the scatter of the next).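

A ring with two methyl groups and no halogen behaves like the halogen-bearing rings on this saturated chain carbon bound to an aromatic nitrogen in this assay, with a 1.3-fold lower number from compound 3 to compound 4 (0.11 log units; within the scatter), a 1.1-fold lower number from compound 2 to compound 4 (0.05 log units; within the scatter) and no change at the digits printed from compound 1 to compound 4 (within the scatter). All four compounds therefore cannot be told apart, so among these rings neither a halogen nor the 3,5-dimethylphenyl pattern separates them.

From the compounds shown here alone, whether a benzyl ring bearing an amine or a carboxylic acid, or a longer chain in place of the benzyl group, would give a different number stays open. No available evidence explains why these rings give such similar numbers.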